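The source may report more compounds than this note shows. Statements on the series, on what has been measured and on what is new or still open speak of the compounds shown alone.

Measured so far:
compound 1, `COc1cc(CSc2cc(Cl)c(-c3nnc(-c4ccc(Cl)cc4)s3)cc2S(=O)(=O)NC(=N)NO)cc(OC)c1OC`, 9550 nM
compound 2, `N=C(NO)NS(=O)(=O)c1cc(-c2nnc(-c3ccc(Cl)cc3)s2)c(Cl)cc1SCc1ccccc1`, 1900 nM

Both numbers come from a functional assay on SF-268 cells (Homo sapiens); on this read-out higher numbers stand for weaker inhibition of growth and lower numbers for stronger inhibition of growth. Within the data shown here, compound 1 stands at the highest of the two numbers; compound 2 is the only neighbour, and the change from compound 1 to compound 2 gives a 5.0-fold lower number from compound 1 to compound 2 (0.70 log units; beyond the scatter), a step made by a 5.0-fold lower number from compound 1 to compound 2 (0.70 log units; beyond the scatter) being a swap of phenyl in place of 3,4,5-trimethoxyphenyl on a saturated chain carbon bound to a sulfur.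

Compound 3, `COc1cc(CSc2cc(Cl)c(-c3nc(-c4ccc(Cl)cc4)no3)cc2S(=O)(=O)NC(=N)NO)cc(OC)c1OC`, differs from compound 1 elsewhere: 3-(4-chlorophenyl)-1,2,4-oxadiazol-5-yl in place of 5-(4-chlorophenyl)-1,3,4-thiadiazol-2-yl on an aromatic carbon. Among the measured compounds shown here, the one measured step, that from compound 1 to compound 2, touches a different part of the shared core, so no measured step bears directly on the change to compound 3. There is nothing here to say which way this change moves the number in this assay or by how much, so the expectation rests on compound 1 alone, and a step no larger than the usual scatter is expected, with a wide range either way. Compound 3 is therefore expected to give 9000 nM, between 2500 nM and 32000 nM, an expected step of a 1.1-fold lower number from compound 1 to compound 3 (0.03 log units; within the scatter).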

Compound 3, concentration for 50% growth inhibition: 2950 nM
Compound 3: the middle estimate sits 3.1-fold (0.48 log units) above what was measured; the measured number falls inside the stated range.
By their numbers in this assay, from the lowest: compounds 2 and 3 (each within the scatter of the next); then compound 1.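

Among these compounds, until this result, the only measured change was to the group on the saturated chain carbon bound to a sulfur. This result shows that the number in this assay also responds to a change on the aromatic carbon, where 3-(4-chlorophenyl)-1,2,4-oxadiazol-5-yl in place of 5-(4-chlorophenyl)-1,3,4-thiadiazol-2-yl gives a 3.2-fold lower number from compound 1 to compound 3 (0.51 log units; beyond the scatter), a modest step but one beyond the scatter. The two groups match in heavy-atom count, ring types and hydrogen-bond counts, with an oxygen entering where a sulfur leaves and the ring atoms arranged differently, yet the number still moves, and nothing measured here says which of these differences is responsible.

The compounds shown leave open whether the same swap would give a similar step with phenyl on the chain carbon, as the only evidence comes from the 3,4,5-trimethoxyphenyl series. They also leave open how far this aromatic carbon tolerates larger departures, such as an amide or a carboxylic acid in place of the whole ring-bearing group.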